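The compounds below may be only part of what the source reports. "The series", "measured", "known", "first", "only" and "open" are said of these compounds alone.

Measured so far in a functional assay on MGC-803 cells (Homo sapiens) for inhibition, read by sulforhodamine B assay; a higher number here means a weaker inhibitor, a lower number a stronger inhibitor:

- compound 1 `CCCc1ccc(NC2=CC(=O)c3nc4n(c3C2=O)[C@H]2OC[C@@H](O)[C@H]2OC4)cc1` gives 1560 nM
- compound 3 `O=C1C(Nc2ccc(C(F)(F)F)cc2)=CC(=O)c2c1nc1n2[C@H]2OC[C@@H](O)[C@H]2OC1` gives 1860 nM
- compound 2 `O=C1C(N2CCCCC2)=CC(=O)c2c1nc1n2[C@H]2OC[C@@H](O)[C@H]2OC1` gives > 4000 nM, which is a limit of the assay and not a number

Compound 1 holds the lowest of the two plain numbers, but compound 3 lies within the usual scatter of it, so neither can be called the stronger inhibitor of the pair. Compound 2 reaches only (the limit of > 4000 nM in this assay, at which 1 of the 3 values shown sits).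

Compound 4 `O=C1C=C(Nc2ccc(I)cc2)C(=O)c2c1nc1n2[C@H]2OC[C@@H](O)[C@H]2OC1` has not yet been tested. Set against compound 1, the change is iodo in place of propyl on an aromatic carbon. Going by the values given here, no step between two measured compounds is available to size this change. What the numbers do show is that compound 1 and compound 3, two compounds in which the aromatic ring carries a different group, sit close together. On that basis the step of a 1.0-fold lower number from compound 1 to compound 4 (0.02 log units; within the scatter) is expected to be small, in no clear direction and not beyond the scatter. Compound 4 is therefore estimated to give about 1500 nM in this assay, most likely between 600 nM and 4000 nM.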

Compound 4, half-maximal inhibitory concentration: 1400 nM
Beside the measured number, compound 4's estimate is 1.1-fold (0.03 log units) above it, and the stated range covers the measured number.
By their numbers in this assay, from the lowest: compounds 4, 1 and 3 (each within the scatter of the next). At a limit, above all of these: compound 2.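

Going by these compounds alone, the first step in this assay that changes only one group on the aromatic ring is a 1.1-fold lower number from compound 1 to compound 4 (0.05 log units; within the scatter). A propyl chain of 3 heavy atoms gives way to a single iodine atom on an aromatic carbon, para to a large group, and the two compounds cannot be told apart in this measurement. This is a single pair, so it shows only that 4-propylphenyl and 4-iodophenyl read alike here, not that this place tolerates every change.

Nothing measured here explains why these two groups read alike. On these data alone, it also remains open whether an amine, a carboxylic acid or a longer chain such as hexyl at this place would move the number beyond the scatter.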